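Moving the Fluorine on the Amide Aryl Ring

The compounds below may be only part of what the source reports. "The series", "measured", "known", "first", "only" and "open" are said of these compounds alone.

Compound 1 `O=C(Nc1cc(-c2ccccc2)nn1-c1ccccc1)c1ccc(F)cc1` is the reference point. Among the compounds with values here, in an assay on CHO cells with metabotropic glutamate receptor 5 (Homo sapiens) as the target (a higher number here means that more compound is needed for the effect, a lower number that less compound is needed), compound 1 gives 30 nM, the lowest of the three numbers measured so far. Compound 2 `O=C(Nc1cc(-c2ccccc2)nn1-c1ccccc1)c1ccccc1Cl` gives 2500 nM, and compound 3 `O=C(Nc1cc(-c2ccccc2)nn1-c1ccccc1)c1cnccn1` gives 200 nM. Both changes away from compound 1 raised the number: an 83-fold higher number from compound 1 to compound 2 (1.92 log units; beyond the scatter), and a 6.7-fold higher number from compound 1 to compound 3 (0.82 log units; beyond the scatter). Between the other two, a 13-fold lower number from compound 2 to compound 3 (1.10 log units; beyond the scatter).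

Compound 4 `O=C(Nc1cc(-c2ccccc2)nn1-c1ccccc1)c1ccccc1F` differs from compound 1 in one place: 2-fluorophenyl in place of 4-fluorophenyl on a carbonyl carbon. The measured step that bears most directly on this is an 83-fold higher number from compound 1 to compound 2 (1.92 log units; beyond the scatter), where the group on the carbonyl carbon went from 4-fluorophenyl to 2-chlorophenyl, so the halogen moved as it does here, but chlorine took the place of fluorine at the same time. That step argues for a higher number for compound 4, beyond the scatter, while its full size cannot be carried over to fluorine with confidence. The expected step is a 10-fold higher number from compound 1 to compound 4 (1.00 log units; beyond the scatter). Compound 4 is estimated at 300 nM, with a range from 60 nM to 1500 nM.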

Compound 4, half-maximal effective concentration: 75 nM
For compound 4 the middle estimate is 4.0-fold (0.60 log units) above the measured one; measured number inside the range.
By their numbers in this assay, from the lowest: compound 1; then compound 4; then compound 3; then compound 2.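

Moving the fluorine alone, with the same atoms joined differently, gives a 2.5-fold higher number from compound 1 to compound 4 (0.40 log units; beyond the scatter) in this assay, so where the fluorine sits on this ring matters, but the step is only modest. Changing the halogen has a far larger effect, since fluoro in place of chloro on the aromatic carbon gives a 33-fold lower number from compound 2 to compound 4 (1.52 log units; beyond the scatter), which shows that most of the large rise seen with the 2-chlorophenyl group goes with chlorine and not with the move alone. The 2-fluorophenyl group also keeps a lower number than pyrazin-2-yl, with a 2.7-fold lower number from compound 3 to compound 4 (0.43 log units; beyond the scatter), and no supporting data are available to explain any of these shifts.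

The compounds shown leave open how a methoxy group or a nitrile in place of the fluorine would compare. They also do not show how an amine or a carboxylic acid on this ring would behave.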